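A few compounds are considered here, and "the series" means these few. Any claim that something is new, unique, unknown or untested is made for them only; others in the source may bear on it.

Two measured compounds set the scene. Compound 1 `COc1cc(C(=O)NO)ccc1CS(=O)(=O)Nc1ccc2c(c1)cc(C)c(=O)n2C` and compound 2 `Cc1cc2ccc(NS(=O)(=O)Cc3ccc(C(=O)NOCc4ccc(O)cc4)cc3)cc2n(C)c1=O` share a core and differ in one outer part of the structure. In a functional assay on THP-1 cells (Homo sapiens) for antiproliferative activity, tested at 20 uM (on this read-out lower numbers stand for a weaker effect and higher numbers for a stronger effect at the one concentration tested), compound 1 gives 0%, and in the same test compound 2 gives 1%. Compound 2 therefore stands alongside compound 1, the two numbers lying within the usual scatter of each other and both close to no measurable effect. Among the compounds with values here, no step between measured compounds is available, so nothing here shows how any single change shifts this read-out. Compound 3 `CC(=O)Oc1ccc(CONC(=O)c2ccc(CS(=O)(=O)Nc3ccc4cc(C)c(=O)n(C)c4c3)cc2)cc1` differs from compound 2 by one change: acetyl in place of hydrogen on an oxygen on an aromatic ring Because compound 2 gives 1% in this assay, compound 3 is expected to stay near it, and the expected step is a number 2 percentage points higher from compound 2 to compound 3 (within the scatter), nothing beyond the scatter. The estimate for compound 3 is 3%, within a range from 0% to 20%.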

Compound 3, a percentage reported as inhibition, at one concentration (the size of the read-out at that concentration, not a potency): 1%
Estimate against measurement, compound 3: 2 percentage points above; the range from low to high includes it.
By their numbers in this assay, from the lowest: compounds 1, 2 and 3 (each within the scatter of the next).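

Within the data shown here, this is the first step between two measured compounds that differ in one place: acetyl in place of hydrogen on an oxygen on an aromatic ring, or 4-hydroxyphenyl to 4-acetoxyphenyl, gives no change at the digits printed from compound 2 to compound 3 (within the scatter) in this assay at the one concentration tested. Capping this hydroxy group as an acetoxy group therefore does not lift the read-out away from close to no measurable effect, so this change at this position shows no gain here. Nothing available explains this outcome.

What the compounds shown leave open is whether any other group on this oxygen, such as a longer chain like butyryl or one carrying an amine, would give a clear effect. Going by these compounds, whether this position can move the read-out at all also stays open, since both compounds of this step lie near no measurable effect.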